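Bromo for Chloro on a Kynurenine 3-Monooxygenase Inhibitor

The compounds below may be only part of what the source reports. "The series", "measured", "known", "first", "only" and "open" are said of these compounds alone.

Measured so far:
compound 1, `COC(=O)C(=O)/C=C(\O)c1cccc(Br)c1`, 2100 nM
compound 2, `O=C(O)C(=O)/C=C(\O)c1cccc(Cl)c1`, 320 nM

In an assay for inhibition of kynurenine 3-monooxygenase (Rattus norvegicus) (on this read-out higher numbers stand for weaker inhibition and lower numbers for stronger inhibition), compound 2 `O=C(O)C(=O)/C=C(\O)c1cccc(Cl)c1` gives 320 nM, the lowest of the two numbers. Compound 1 `COC(=O)C(=O)/C=C(\O)c1cccc(Br)c1` gives 2100 nM in this assay, a gap beyond the scatter; the two compounds differ in more than one place, so no single step can be read from them. Compound 3 `O=C(O)C(=O)/C=C(\O)c1cccc(Br)c1` arises from compound 2 by bromo in place of chloro on an aromatic carbon. Going by the values given here, no measured pair isolates this change. The step is expected to be a 1.1-fold lower number from compound 2 to compound 3 (0.03 log units; within the scatter), not beyond the scatter in either direction. Compound 3 is estimated at 300 nM, between 120 nM and 800 nM.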

Compound 3, half-maximal inhibitory concentration: 1700 nM
Estimate against measurement, compound 3: 5.7-fold (0.75 log units) below; the measured number lies above the stated range.
By their numbers in this assay, from the lowest: compound 2; then compounds 3 and 1 (each within the scatter of the next).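

In this assay the halogen on this aromatic carbon proves not to be interchangeable, with a 5.3-fold higher number from compound 2 to compound 3 (0.73 log units; beyond the scatter), so chloro gives the lower number of the two. With bromo in place, hydrogen in place of methyl on the oxygen next to a carbonyl group leaves no step beyond the scatter, at a 1.2-fold lower number from compound 1 to compound 3 (0.09 log units; within the scatter). No data at hand account for either step. As far as these compounds go, whether fluoro or methoxy on the same aromatic carbon would track chloro or bromo remains open. So does whether the methyl group on that oxygen would matter with chloro on the ring.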